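Formamide-capped ester on the beta-lactone scaffold: what to expect

The source may report more compounds than this note shows. Statements on the series, on what has been measured and on what is new or still open speak of the compounds shown alone.

Compound 1 `CCCCCCCCCCC[C@@H](C[C@@H]1OC(=O)[C@H]1CCCCCC)OC(=O)[C@H](CC(C)C)NC(=O)OC(C)(C)C` — > 25000 nM
Compound 2 `CCCCCCCCCCC[C@@H](C[C@@H]1OC(=O)[C@H]1CCCCCC)OC(=O)CCC(C)C` — > 25000 nM

In an assay on COS-7 cells for inhibition of diacylglycerol lipase-alpha (Homo sapiens), read by scintillation counting (on this read-out higher numbers stand for weaker inhibition and lower numbers for stronger inhibition), compound 1 reaches only a limit of the assay, > 25000 nM. In this assay compound 2 likewise gives only a limit, > 25000 nM. Compound 2 therefore stands at the limit of > 25000 nM in this assay, at which 2 of the 2 values shown sit, with no number to mark it out. Going by the values given here, the one change between the two measured compounds, a step that the two limits leave unreadable from compound 1 to compound 2, has a size that cannot be read, since both ends of it sit at the same limit.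

Compound 3 `CCCCCCCCCCC[C@@H](C[C@@H]1OC(=O)[C@H]1CCCCCC)OC(=O)[C@H](C)NC=O` differs from compound 2 by a group of 5 heavy atoms (3 carbon, 1 nitrogen, 1 oxygen; no ring) in place of a group of 5 heavy atoms (5 carbon; no ring), on a carbonyl carbon; in words, a group of 5 heavy atoms (3 carbon, 1 nitrogen, 1 oxygen; no ring) in place of a group of 5 heavy atoms (5 carbon; no ring), on a carbonyl carbon. Among the compounds with values here, no measured step gives a readable size that bears on this change, and the only comparison available is unreadable. There is thus no ground on which to expect a step beyond the scatter in this assay in either direction. Compound 3 is accordingly expected to give about 30000 nM, between 5000 nM and 120000 nM, most likely again as a limit. The step this expectation implies, a step that the limit leaves unreadable from compound 2 to compound 3, is estimated to be essentially flat.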

Compound 3, half-maximal inhibitory concentration: 43 nM
Estimate against measurement, compound 3: 700-fold (2.84 log units) above; the whole stated range lies above it.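

In this assay, going by these compounds alone, the exchange of isopentyl for the group of 3 carbon, 1 nitrogen and 1 oxygen, on a carbonyl carbon whose other neighbours are oxygen next to a carbonyl group, gives the first readable step: an at least 580-fold lower number from compound 2 to compound 3 (2.76 log units; beyond the scatter). The earlier pair could not show this, as the step between its two compounds cannot be read, whereas this change shows that the position can carry a large difference in this assay with the rest of the shared core unchanged. Compound 3 is thus the only compound shown with a number rather than a limit, and the other two values sit together at that limit: the limit of > 25000 nM in this assay, at which 2 of the 3 values shown sit.

The entering group differs from isopentyl in several ways at once, bringing in nitrogen, a double bond, a hydrogen-bond donor, a hydrogen-bond acceptor and a defined stereocentre, and the compounds shown do not separate these features. On these data alone, it remains open how a free amine or an acetyl group in place of the formyl group would read in this assay, and whether the opposite configuration at the defined stereocentre would keep the step.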